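Swapping the aminophenyl for a dichlorophenyl on the ketone

A few compounds are considered here, and "the series" means these few. Any claim that something is new, unique, unknown or untested is made for them only; others in the source may bear on it.

Measured so far:
Compound 1, `COc1ccc(-c2cc(/C=C/C(=O)c3ccc(N)cc3)[nH]n2)cc1`: 1670 nM
Compound 2, `COc1cc(-c2cc(/C=C/C(=O)c3ccc(N)cc3)[nH]n2)cc(OC)c1OC`: 1350 nM

Both compounds were tested in a functional assay on RXF 393 cells (Homo sapiens) for inhibition, read by sulforhodamine B assay, with a stated time of 48 h; a higher number here means a weaker inhibitor of growth, a lower number a stronger inhibitor of growth. Compound 2 gives 1350 nM and holds the lower of the two numbers, but compound 1 with 1670 nM lies within the usual scatter of it, so the two cannot be told apart on these data.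

Compound 3, `COc1cc(-c2cc(/C=C/C(=O)c3ccc(Cl)c(Cl)c3)[nH]n2)cc(OC)c1OC`, has not been measured yet. It differs from compound 2 in one place: 3,4-dichlorophenyl in place of 4-aminophenyl on a carbonyl carbon. Going by the values given here, no measured pair here shows what such a change does, so there is no step to lean on.

In this assay the step from compound 2 to compound 3 is expected to be small, a 1.5-fold higher number from compound 2 to compound 3 (0.17 log units; within the scatter), with no clear direction beyond the scatter and wide uncertainty. Compound 3 is therefore expected to give about 2000 nM, most likely between 500 nM and 8000 nM.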

Compound 3, concentration for 50% growth inhibition: 2700 nM
Compound 3: middle estimate off by 1.4-fold (0.13 log units), on the low side; low and high end bracket the measured number.
By their numbers in this assay, from the lowest: compounds 2, 1 and 3 (each within the scatter of the next).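

Putting 3,4-dichlorophenyl in place of 4-aminophenyl on the carbonyl carbon gives a 2.0-fold higher number from compound 2 to compound 3 (0.30 log units; within the scatter) in this assay and so does not separate the two compounds. Going by these compounds alone, this is the first view of this position, and it shows that a ring with two chlorines and no hydrogen-bond donor or acceptor cannot be told apart here from the ring bearing the amine. No supporting measurement bears on this result, so no reason for it can be offered.

Still open, on these data alone, is whether other groups at this place, such as an unsubstituted phenyl, a 4-hydroxyphenyl or a 4-carboxyphenyl, would stand clear of the scatter. As far as these compounds go, it is also open whether 3,4-dichlorophenyl would behave the same way on the core of compound 1.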